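The source may hold more compounds than are shown below. What is called first, only, known or untested is meant among the compounds shown, and "the series" means these compounds.

Of the compounds shown here, three built on one shared core have been measured in a functional assay on CCRF-CEM cells (Homo sapiens) for cytotoxicity, read by XTT assay, with a stated time of 3 days; on this read-out higher numbers stand for weaker inhibition and lower numbers for stronger inhibition. There, compound 1 `OC[C@H]1O[C@@H](n2cc(F)c3c(-c4ccco4)ncnc32)[C@H](O)[C@@H]1O` gives 1400 nM, compound 2 `OC[C@H]1O[C@@H](n2cc(F)c3c(-c4ccoc4)ncnc32)[C@H](O)[C@@H]1O` gives 1000 nM and compound 3 `OC[C@H]1O[C@@H](n2cc(Cl)c3c(-c4ccco4)ncnc32)[C@H](O)[C@@H]1O` gives 3800 nM. Compound 3 has the highest number of the three, which makes it the weakest inhibitor so far.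

Compound 4 `OC[C@H]1O[C@@H](n2cc(Cl)c3c(-c4ccoc4)ncnc32)[C@H](O)[C@@H]1O` differs from compound 3 by a single swap, furan-3-yl in place of furan-2-yl on an aromatic carbon. The same swap has been measured once, in the fluoro pair, as a 1.4-fold lower number from compound 1 to compound 2 (0.15 log units; within the scatter). That step is small and lies within the scatter. The other measured step, a 2.7-fold higher number from compound 1 to compound 3 (0.43 log units; beyond the scatter), exchanges fluoro for chloro and leaves the furan unchanged. A single pair is thin evidence, and it may not carry over to the chloro compounds.

The expected change is therefore slight and downward, probably within the scatter, as a 1.3-fold lower number from compound 3 to compound 4 (0.12 log units; within the scatter). In this assay, the estimate for compound 4 is 2900 nM, with an expected range of 1400 nM to 6000 nM.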

Compound 4, half-maximal inhibitory concentration: 1100 nM
Compound 4: the middle estimate sits 2.6-fold (0.42 log units) above what was measured; measured number outside the range, below it.
By their numbers in this assay, from the lowest: compounds 2, 4 and 1 (each within the scatter of the next); then compound 3.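

On the chloro compounds, furan-3-yl in place of furan-2-yl gives a 3.5-fold lower number from compound 3 to compound 4 (0.54 log units; beyond the scatter) in this assay, a step beyond the scatter, unlike the same swap on the fluoro pair. Chloro in place of fluoro also reads differently once furan-3-yl is present: a 1.1-fold higher number from compound 2 to compound 4 (0.04 log units; within the scatter), whereas the same change with furan-2-yl present was beyond the scatter. The two groups may therefore not act independently, but that remains unproven, since the gap between the two furan steps is itself within what two such steps can show: the same change on two cores in this assay, a 1.4-fold lower number (0.15 log units; within the scatter) from compound 1 to compound 2 and a 3.5-fold lower number (0.54 log units; beyond the scatter) from compound 3 to compound 4, 2.5-fold (0.39 log units) apart, within the scatter of two such steps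

Going by these compounds, only two furans and two halogens appear here, so it remains open how a thiophene or an amine would read on the aromatic carbon that carries the furan. Bromo in place of chloro is equally open.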